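This account rests on a few compounds, and the source may have more. Where it says the series, first, only, none or still open, it means among the compounds named here.

Compound 2 `COc1ccccc1CN(C)Cc1ccc(/C=C2\COc3cc(OC)c(OC)cc3C2=O)cc1O` gives 1030 nM in an assay on isolated protein for inhibition of Amine oxidase [flavin-containing] B (Homo sapiens), read by fluorescence, with a stated time of 30 min (a lower number here means a stronger inhibitor, a higher number a weaker inhibitor), the highest of the two numbers in hand; compound 1 `COc1cc2c(cc1OC)C(=O)/C(=C/c1cccc(O)c1)CO2` gives 190 nM, a lower number beyond the scatter. Compound 3 `CCN(Cc1ccccc1)Cc1ccc(/C=C2\COc3cc(OC)c(OC)cc3C2=O)cc1O` differs from compound 2 only in one place: benzyl(ethyl)amino in place of (2-methoxybenzyl)(methyl)amino on a saturated chain carbon bound to an aromatic carbon. For the measured compounds named here, no measured pair shows such a change, so the expected step from compound 2 to compound 3 is set within the scatter, direction open, at a 1.1-fold lower number from compound 2 to compound 3 (0.06 log units; within the scatter). Compound 3 is therefore estimated at 900 nM in this assay, with a range from 350 nM to 2500 nM.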

Compound 3, half-maximal inhibitory concentration: 1720 nM
Estimate against measurement, compound 3: 1.9-fold (0.28 log units) below; low and high end bracket the measured number.
By their numbers in this assay, from the lowest: compound 1; then compounds 2 and 3 (each within the scatter of the next).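

In this assay, benzyl(ethyl)amino in place of (2-methoxybenzyl)(methyl)amino on a saturated chain carbon bound to an aromatic carbon gives a 1.7-fold higher number from compound 2 to compound 3 (0.22 log units; within the scatter) and so shows that this exchange, which drops the methoxy group and swaps methyl for ethyl, moves the number only within the scatter. The larger change, (benzyl(ethyl)amino)methyl in place of hydrogen on an aromatic carbon, gives a 9.1-fold higher number from compound 1 to compound 3 (0.96 log units; beyond the scatter) and stands beyond the scatter. No measurement in hand bears on the reason for either step. From the compounds shown here alone, whether a dimethylamino or morpholine group at this place would move the number beyond the scatter remains open.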